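The source may report more compounds than this note shows. Statements on the series, on what has been measured and on what is new or still open speak of the compounds shown alone.

Measured so far:
compound 1 `ClCc1ccc(Cn2cnc3c(Cl)ncnc32)cc1` — 3160 nM
compound 2 `Nc1nc(Cl)c2ncn(Cc3ccccc3CCl)c2n1` — 6310 nM

In a functional assay on IGROV-1 cells (Homo sapiens) for cytotoxicity, read by sulforhodamine B assay, with a stated time of 48 h (a lower number here means a stronger inhibitor of growth, a higher number a weaker inhibitor of growth), compound 1 gives 3160 nM, the lower of the two numbers, yet compound 2 gives 6310 nM, which lies within the scatter of compound 1. Compound 3 `Nc1nc(Cl)c2ncn(Cc3ccc(CCl)cc3)c2n1` remains unmeasured. It differs from compound 1 by amino in place of hydrogen on an aromatic carbon. Going by the values given here, no pair of measured compounds differs in this way alone, so the step has no direct anchor. Compound 2 also carries an amino group and sits within the scatter of compound 1, so no step beyond the scatter is expected in this assay. Compound 3 is expected near 5000 nM, within 2000 nM to 12500 nM. The expected step is a 1.6-fold higher number from compound 1 to compound 3 (0.20 log units; within the scatter), inside the scatter.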

Compound 3, concentration for 50% growth inhibition: 9120 nM
Compound 3: the middle estimate sits 1.8-fold (0.26 log units) below what was measured; the range from low to high includes it.
By their numbers in this assay, from the lowest: compounds 1, 2 and 3 (each within the scatter of the next, the first and the last beyond it).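

In this assay, going by these compounds alone, amino in place of hydrogen on the aromatic carbon between two ring nitrogen atoms gives a 2.9-fold higher number from compound 1 to compound 3 (0.46 log units; beyond the scatter), the first step that isolates this position. The step is modest, but it lies beyond the scatter and points to weaker growth inhibition, so amino at this position brings no gain on the core of compound 1. Nothing available bears on the reason for this step. The compounds shown leave open whether a methylamino or methoxy group on this carbon would give a step of similar size. They also leave open whether a step of this size would recur on a core with a different group in place of the chloro group.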